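One Methyl on an Aromatic Oxygen in a Cytotoxicity Assay

The source may hold more compounds than are shown below. What is called first, only, known or untested is meant among the compounds shown, and "the series" means these compounds.

Measured compounds:
compound 1 `Oc1ccccc1CNc1ncnc2c1ncn2C1CCCCO1` gives > 100000 nM
compound 2 `COc1ccccc1CNc1ncnc2c1ncn2C1CCCCO1` gives 97000 nM
compound 3 `COc1cc(CNc2ncnc3c2ncn3C2CCCCO2)ccc1O` gives > 100000 nM

All three compounds were tested in an ADME assay on K562 cells (Homo sapiens) for cytotoxicity, with a stated time of 72 h; a lower number here means a stronger inhibitor, a higher number a weaker inhibitor. Compound 1 gives > 100000 nM, which is a limit of the assay and not a number. Compound 2, which carries a single extra methyl, gives 97000 nM. The change from compound 1 to compound 2 is methyl in place of hydrogen on an oxygen on an aromatic ring and it made a step of an at least 1.0-fold lower number from compound 1 to compound 2 (0.01 log units; that floor lies within the scatter), a step that cannot be read as a real difference. Two of the three values sit at the limit of > 100000 nM in this assay, at which 2 of the 3 values shown sit, which marks how little the whole set does in this assay.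

Compound 3 gives > 100000 nM, again a limit of the assay rather than a number. How the core of compound 3 differs from the core of compound 1 is not broken down here.

Compound 4 `COc1ccc(CNc2ncnc3c2ncn3C2CCCCO2)cc1OC` has not yet been measured. It differs from compound 3 by methyl in place of hydrogen on an oxygen on an aromatic ring, the same change that was made from compound 1 to compound 2, and at the same kind of place. On the strength of the step of an at least 1.0-fold lower number from compound 1 to compound 2 (0.01 log units; that floor lies within the scatter) from compound 1 to compound 2, the step from compound 3 to compound 4 is expected to be a number no higher from compound 3 to compound 4 (the limit leaves the size open), essentially no movement. Compound 4 is therefore estimated at 100000 nM, with the value most likely falling between 60000 nM and 200000 nM, and with a good chance that this assay again reports only a limit.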

Compound 4, half-maximal inhibitory concentration: > 100000 nM
Compound 4: no number, only a limit; the forecaster's own chance of this, stated with the estimate: 60%; the middle value sits exactly at the limit.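

In this assay compound 4 gives > 100000 nM, a limit of the assay and not a number. Within the data shown here, compound 3 also stands at a limit, so no step from compound 3 to compound 4 can be read. The compounds shown leave open what real values compound 1, compound 3 and compound 4 have, and so whether methyl in place of hydrogen on this oxygen changes anything in this assay.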